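The source may report more compounds than this note shows. Statements on the series, on what has been measured and on what is new or still open speak of the compounds shown alone.

In a functional assay on NCI-H460 cells (Homo sapiens) for cytotoxicity, read by MTT assay, with a stated time of 72 h (on this read-out lower numbers stand for stronger inhibition and higher numbers for weaker inhibition), compound 1 (`CC1CCN(Cc2ccc3nc(NC(=O)N/N=C/c4c[nH]c5ccccc45)sc3c2)CC1`) gives 4130 nM. This sits within the scatter of compound 2 (`CN(C)Cc1ccc2nc(NC(=O)N/N=C/c3c[nH]c4ccccc34)sc2c1`) at 2550 nM and compound 3 (`CCN(CC)Cc1ccc2nc(NC(=O)N/N=C/c3c[nH]c4ccccc34)sc2c1`) at 3140 nM. The three measured steps all exchange the amine on the saturated chain carbon: a 1.6-fold lower number from compound 1 to compound 2 (0.21 log units; within the scatter), a 1.3-fold lower number from compound 1 to compound 3 (0.12 log units; within the scatter) and a 1.2-fold higher number from compound 2 to compound 3 (0.09 log units; within the scatter). All three lie within the scatter, so the amine exchange shows no measurable change on this read-out.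

Compound 4 (`CC1CCN(Cc2ccc3nc(NC(=O)N/N=C/c4cn(Cc5ccc(C(C)(C)C)cc5)c5ccccc45)sc3c2)CC1`) keeps the 4-methylpiperidin-1-yl of compound 1 and has 4-(tert-butyl)benzyl in place of hydrogen on an aromatic nitrogen. Going by the values given here, no measured step touches that nitrogen, so the amine steps give no direct guide to its size or direction. The change is far larger than a swap of amines, and a move beyond the scatter towards a lower number is expected, though this is a judgement and not a measured trend. The expected change is a 5.9-fold lower number from compound 1 to compound 4 (0.77 log units; beyond the scatter). For compound 4 the estimated value is 700 nM, with an expected range of 120 nM to 3800 nM.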

Compound 4, half-maximal inhibitory concentration: 3370 nM
The estimate for compound 4 lay 4.8-fold (0.68 log units) below the measured number; low and high end bracket the measured number.
By their numbers in this assay, from the lowest: compounds 2, 3, 4 and 1 (each within the scatter of the next).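

In this assay the step to the aromatic nitrogen gives a 1.2-fold lower number from compound 1 to compound 4 (0.09 log units; within the scatter) and so adds a result that the amine steps could not supply. On the core of compound 1, this nitrogen of the five-membered aromatic ring can therefore carry 4-(tert-butyl)benzyl, with its 11 heavy atoms and six-membered aromatic ring, and the number still stays within the scatter. No available measurement bears on the reason for this result.

The compounds shown leave open whether a methyl group or a 2-aminoethyl chain on that nitrogen would move the number beyond the scatter. Also open, going by these compounds, is whether 4-(tert-butyl)benzyl gives the same result when dimethylamino or diethylamino replaces 4-methylpiperidin-1-yl.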